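Lengthening the amine substituent in a triazolopyrimidine series

This account rests on a few compounds, and the source may have more. Where it says the series, first, only, none or still open, it means among the compounds named here.

Measured compounds:
Compound 1, `OCCCNc1nc(-c2ccccc2)nc2c1nnn2Cc1ccccc1`, gives 21400000 nM in an assay on isolated protein for binding affinity to adenosine receptor A1 (Bos taurus); a higher number here means a weaker inhibitor, a lower number a stronger inhibitor.
Compound 2, `CCCNc1nc(-c2ccccc2)nc2c1nnn2Cc1ccccc1`, gives 37000000 nM in this assay.
Compound 3, `CNc1nc(-c2ccccc2)nc2c1nnn2Cc1ccccc1`, gives 353000000 nM in this assay.

Compound 3 stands at the highest of the three numbers in this assay. The nearest is compound 2, reached by a 9.5-fold higher number from compound 2 to compound 3 (0.98 log units; beyond the scatter); the furthest is compound 1, reached by a 16-fold higher number from compound 1 to compound 3 (1.22 log units; beyond the scatter). Between compound 1 and compound 2 the step is a 1.7-fold higher number from compound 1 to compound 2 (0.24 log units; within the scatter).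

Compound 4, `c1ccc(Cn2nnc3c(NC4CCC4)nc(-c4ccccc4)nc32)cc1`, differs from compound 3 by cyclobutyl in place of methyl on a nitrogen on an aromatic ring. Going by the values given here, the steps that bear on it are those in which a small group on this nitrogen was exchanged for hydrogen: a 9.5-fold higher number from compound 2 to compound 3 (0.98 log units; beyond the scatter) and a 16-fold higher number from compound 1 to compound 3 (1.22 log units; beyond the scatter). Both went the same way and both were beyond the scatter, so restoring carbon atoms at this nitrogen, now as a cyclobutyl ring, is expected to lower the number again. The step from compound 3 to compound 4 is estimated as a 14-fold lower number from compound 3 to compound 4 (1.15 log units; beyond the scatter), in the direction of a stronger inhibitor. For compound 4 the expected value in this assay is 25000000 nM, with a range of 5000000 nM to 120000000 nM.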

Compound 4, inhibition constant: 5000000 nM
For compound 4 the middle estimate is 5.0-fold (0.70 log units) above the measured one, and the stated range covers the measured number.
By their numbers in this assay, from the lowest: compound 4; then compounds 1 and 2 (each within the scatter of the next); then compound 3.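

Going by these compounds alone, at this nitrogen on an aromatic ring, the earlier compounds carried only open chains, and in this assay compound 4 now shows that a cyclobutyl group can reach a lower number than any of them. Cyclobutyl in place of methyl gives the largest change seen at this position so far (a 71-fold lower number from compound 3 to compound 4 (1.85 log units; beyond the scatter)), and compound 4 also passes the two longer chains, with cyclobutyl in place of propyl (a 7.4-fold lower number from compound 2 to compound 4 (0.87 log units; beyond the scatter)) and in place of 3-hydroxypropyl (a 4.3-fold lower number from compound 1 to compound 4 (0.63 log units; beyond the scatter)), both beyond the scatter, so the gain at this position is not limited to what those chains achieved and compound 4 is the strongest inhibitor of the four. No measurement here explains this difference between the ring and the chains.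

The compounds shown cannot separate the presence of a ring from the number of carbons, as an open butyl chain or a cyclopropyl group would begin to do. On these data alone, whether the number keeps falling with a larger ring such as cyclopentyl or cyclohexyl also remains open.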